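Extending the alkoxy chain from methoxy to ethoxy

The source may report more compounds than this note shows. Statements on the series, on what has been measured and on what is new or still open speak of the compounds shown alone.

In a functional assay on RAW264.7 cells (Mus musculus) for inhibition, read by Griess assay, with stated times of 1 h and 24 h (on this read-out lower numbers stand for stronger inhibition and higher numbers for weaker inhibition), compound 3 (`COc1ccccc1C1CC(=O)c2ccccc2O1`) gives 47300 nM, compound 2 (`CCCCCOc1ccccc1C1CC(=O)c2ccccc2O1`) gives 39200 nM and compound 1 (`O=C1CC(c2ccccc2OCc2ccc(F)cc2)Oc2ccccc21`) gives 28200 nM. These three values lie within the scatter of one another, so compound 3 has no distinct rank among them.

The next entry is compound 4 (`CCOc1ccccc1C1CC(=O)c2ccccc2O1`), which carries methyl in place of hydrogen on a saturated chain carbon bound to an oxygen on an aromatic ring. In other words, methoxy becomes ethoxy.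

Three measured steps change the same position. The step with butyl and hydrogen exchanged is a 1.2-fold higher number from compound 2 to compound 3 (0.08 log units; within the scatter). The step with 4-fluorophenyl and hydrogen exchanged is a 1.7-fold higher number from compound 1 to compound 3 (0.22 log units; within the scatter), and the step with 4-fluorophenyl and butyl exchanged is a 1.4-fold higher number from compound 1 to compound 2 (0.14 log units; within the scatter). All three stay within the scatter, even though each exchanges a larger group than methyl. No step beyond the scatter is therefore expected for this smaller change, and no direction can be claimed with confidence. The estimate amounts to a 1.1-fold lower number from compound 3 to compound 4 (0.03 log units; within the scatter), an expected difference that is not meaningful.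

For compound 4, the estimated value is 44000 nM, with an expected range from 26000 nM to 72000 nM.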

Compound 4, half-maximal inhibitory concentration: 38500 nM
Beside the measured number, compound 4's estimate is 1.1-fold (0.06 log units) above it, within the range that was stated.
By their numbers in this assay, from the lowest: compounds 1, 4, 2 and 3 (each within the scatter of the next).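

In this assay, methoxy to ethoxy, the smallest exchange read so far at this position, gives a 1.2-fold lower number from compound 3 to compound 4 (0.09 log units; within the scatter) and so adds a step within the scatter at the short end of the chain. Set against the longer chain of compound 2, the ethoxy compound gives a 1.0-fold lower number from compound 2 to compound 4 (0.01 log units; within the scatter) as the step, and the exchange of 4-fluorophenyl for methyl gives a 1.4-fold higher number from compound 1 to compound 4 (0.14 log units; within the scatter) as the step, so compound 4 cannot be told apart from either. Among the compounds shown here, with hydrogen, methyl, butyl and 4-fluorophenyl now compared on this saturated chain carbon, all of the steps among compounds 1 to 4 stay within the scatter, and this position shows no readable dependence on the group it carries, with no compound going against that within this set.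

No measurement is available that would explain this flat result. Still open, as far as these compounds go, is whether any group on this chain can produce a step beyond the scatter, for example an amine or a carboxylic acid at the end of the alkoxy chain, and whether the same flatness holds when the shared core itself is changed.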